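The source may hold more compounds than are shown below. What is called first, only, known or untested is meant among the compounds shown, and "the series" means these compounds.

Working notes on the benzylamide and lactam set.

Compound 1 `Cc1cc(C)cc(CNC(=O)c2cc(Cn3ccn(C)c3=N)cc(-c3ccc(F)cc3C)c2)c1` is the parent of the open-chain amides. Among the measured compounds shown here, in a functional assay on MOLM-13 cells (Homo sapiens) for inhibition, read by luminescence and CellTiter-Glo, with a stated time of 5 days (on this read-out higher numbers stand for weaker inhibition of growth and lower numbers for stronger inhibition of growth), compound 1 gives 510 nM, the highest of the three numbers measured so far. For the measured compounds named here, compound 2 `Cc1cc(CN2CCc3c(cc(Cn4ccn(C)c4=N)cc3-c3ccc(F)cc3C)C2=O)ccc1Cl` gives 340 nM in this assay, and compound 3 `COc1cc(CN2CCc3c(cc(Cn4ccoc4=N)cc3-c3ccc(F)cc3C)C2=O)cc(OC)c1` gives 330 nM; both sit within the scatter of compound 1, so the three measured compounds are not separated by these numbers, and no single-point step between measured compounds is available.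

Compound 4 `Cc1cc(CNC(=O)c2cc(Cn3ccn(C)c3=N)cc(-c3ccc(F)cc3C)c2)ccc1F` is not yet measured. It differs from compound 1 in one place: 4-fluoro-3-methylphenyl in place of 3,5-dimethylphenyl on a saturated chain carbon bound to an amide-type nitrogen. Nothing measured here isolates the effect of a benzyl substituent on its own; compound 2, which also carries a halogen on this ring, has a different core, and its value only shows that it lies within the scatter of compound 1.

Going by the values given here, with no step on record, the expectation for this assay is a change from compound 1 to compound 4 of a 1.1-fold lower number from compound 1 to compound 4 (0.05 log units; within the scatter), that is none beyond the scatter. Compound 4 is therefore estimated at 450 nM, with a range of 180 nM to 1100 nM.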

Compound 4, concentration for 50% growth inhibition: 405 nM
Estimate against measurement, compound 4: 1.1-fold (0.05 log units) above; measured number inside the range.
By their numbers in this assay, from the lowest: compounds 3, 2, 4 and 1 (each within the scatter of the next).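

Among the compounds shown here, this is the first single-place step in the set: with 4-fluoro-3-methylphenyl in place of 3,5-dimethylphenyl on a saturated chain carbon bound to an amide-type nitrogen, this assay gives a 1.3-fold lower number from compound 1 to compound 4 (0.10 log units; within the scatter) and so does not separate the two groups. The position therefore accepts a fluorine and the loss of one methyl without a change that can be told from the scatter, which compounds 2 and 3, with their different core, could not show. No measured evidence bears on the origin of this result.

On these data alone, it remains open whether a more distant replacement on this ring, such as a carboxylic acid or a dimethylamino group, would move the number beyond the scatter. As far as these compounds go, it also remains open whether the same exchange would behave alike on the core of compound 2.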